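Replacing a Pyridylmethyl Arm with a Fluorobenzyl Arm

The source may report more compounds than this note shows. Statements on the series, on what has been measured and on what is new or still open speak of the compounds shown alone.

Of the compounds shown here, three built on one shared core have been measured in an assay on HEK293 cells for inhibition of Steryl-sulfatase (Homo sapiens), tested at 0.1 uM; on this read-out higher numbers stand for a stronger effect at the one concentration tested and lower numbers for a weaker effect. Compound 1 `CN(CCCN1CCCCC1)c1ccc(C(=O)N2CCc3ccc(OS(N)(=O)=O)cc3C2)cc1` gives 17.4%, compound 2 `CCN(Cc1ccccn1)c1cccc(C(=O)N2CCc3ccc(OS(N)(=O)=O)cc3C2)c1` gives 6.5%, and compound 3 `CCCN(CCC)c1ccc(C(=O)N2CCc3ccc(OS(N)(=O)=O)cc3C2)cc1` gives 36.6%. Compound 2 therefore stands lowest of the three; compound 1 is nearest to it and compound 3 furthest, and both gaps lie beyond the scatter. Within the data shown here, the only measured step that alters a single place is a number 19.2 percentage points higher from compound 1 to compound 3 (beyond the scatter), a modest gain, but it concerns the amino substituent on the aromatic ring rather than the arm that sets compound 4 apart.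

Compound 4 `CCN(Cc1ccc(F)cc1)c1cccc(C(=O)N2CCc3ccc(OS(N)(=O)=O)cc3C2)c1` differs from compound 2 in one place: 4-fluorophenyl in place of pyridin-2-yl on a saturated chain carbon bound to a nitrogen on an aromatic ring. Among the measured compounds shown here, no measured pair bears on this exchange, since compound 2 is the only compound carrying an ethyl((pyridin-2-yl)methyl)amino group, and no compound carries an ethyl(4-fluorobenzyl)amino group. With nothing to lean on but the low value of compound 2 in this assay, the writer expects no step beyond the scatter in either direction. The expected step is a number 3.5 percentage points higher from compound 2 to compound 4 (within the scatter). Compound 4 is accordingly estimated at 10%, with a range from 0% to 25%.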

Compound 4, a percentage reported as inhibition, at one concentration (the size of the read-out at that concentration, not a potency): 10.9%
Compound 4: middle estimate off by 0.9 percentage points, on the low side, within the range that was stated.
By their numbers in this assay, from the lowest: compounds 2, 4 and 1 (each within the scatter of the next, the first and the last beyond it); then compound 3.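

In this assay, among these compounds, putting 4-fluorophenyl in place of pyridin-2-yl on a saturated chain carbon bound to a nitrogen on an aromatic ring gives a number 4.4 percentage points higher from compound 2 to compound 4 (within the scatter), the first reading of any change to this arm. At this position, a ring with one hetero atom and one hydrogen-bond acceptor can therefore give way to a carbon-only ring bearing fluorine without the single-concentration read-out separating the two compounds, although this one pair cannot show how far that holds for other groups. No measured evidence bears on why the two compounds read alike, and the data offer no explanation for it.

As far as these compounds go, it remains open whether any group at this place would give a step beyond the scatter, for example unsubstituted phenyl, pyridin-3-yl, cyclohexyl, or a phenyl ring carrying a carboxylic acid or a methoxy group. From the compounds shown here alone, it also remains open whether compound 2 and compound 4 would stay together at other concentrations, or whether the same exchange would read alike if the ethyl group on the nitrogen gave way to a longer chain such as propyl.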